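This account rests on a few compounds, and the source may have more. Where it says the series, first, only, none or still open, it means among the compounds named here.

Of the compounds shown here, three built on a shared core have been measured in a functional assay on HepG2 cells (Homo sapiens) for cytotoxicity, read by sulforhodamine B assay; a higher number here means a weaker inhibitor, a lower number a stronger inhibitor. Compound 1 `O=C(c1ccc(Cl)cc1)c1cc2c(-c3cccnc3)nn(-c3ccccc3)c2[nH]c1=O` gives 9 ug/mL, the highest of the three numbers. Compound 2 `O=C(c1ccc(F)cc1)c1cc2c(-c3cccnc3)nn(-c3ccccc3)c2[nH]c1=O` gives 7.8 ug/mL, and compound 3 `CCOC(=O)c1cc2c(-c3cccnc3)nn(-c3ccccc3)c2nc1-c1cccnc1` gives 3.75 ug/mL. Compound 4 `Cc1ccc(C(=O)c2cc3c(-c4cccnc4)nn(-c4ccccc4)c3[nH]c2=O)cc1` has not yet been measured; it differs from compound 1 by methyl in place of chloro on an aromatic carbon. Among the measured compounds shown here, the only measured step at that same place is a 1.2-fold lower number from compound 1 to compound 2 (0.06 log units; within the scatter), which stayed within the scatter. Compound 3 differs from compound 1 in several places at once, so its lower number says nothing about this single exchange. The expected step in this assay is therefore no change at the digits printed from compound 1 to compound 4 (within the scatter), within the scatter. Compound 4 is accordingly estimated at 9 ug/mL, between 5 ug/mL and 16 ug/mL.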

Compound 4, half-maximal inhibitory concentration: 8.85 ug/mL
Beside the measured number, compound 4's estimate is 1.0-fold (0.01 log units) above it, within the range that was stated.
By their numbers in this assay, from the lowest: compound 3; then compounds 2, 4 and 1 (each within the scatter of the next).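

With methyl in place of chloro, this assay shows a 1.0-fold lower number from compound 1 to compound 4 (0.01 log units; within the scatter), and with methyl in place of fluoro it shows a 1.1-fold higher number from compound 2 to compound 4 (0.05 log units; within the scatter). The earlier compounds shown here compared only two halogens here, whereas this result shows that a carbon group on this aromatic carbon also stays within the scatter of both. No measurement shown accounts for this lack of separation. The compounds shown leave open whether an amine, a carboxylic acid or a longer chain at this place would shift the number beyond the scatter.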